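Aminothiophene diester imines: the four-fluorophenyl step

The source may hold more compounds than are shown below. What is called first, only, known or untested is meant among the compounds shown, and "the series" means these compounds.

Measured so far in a functional assay on MCF7 cells (Homo sapiens) for inhibition, read by MTT assay, with a stated time of 48 h; on this read-out lower numbers stand for stronger inhibition and higher numbers for weaker inhibition:
compound 1, `CCOC(=O)c1c(N)sc(/N=C/c2ccccc2)c1C(=O)OCC`, 6100 nM;
compound 2, `CCOC(=O)c1c(N)sc(/N=C/c2ccco2)c1C(=O)OCC`, 62200 nM;
compound 3, `CCOC(=O)c1c(N)sc(/N=C/c2ccc(C)cc2)c1C(=O)OCC`, 8900 nM.

Compound 3 stands second highest of the three numbers in this assay. Its nearest neighbour is compound 1, with a 1.5-fold higher number from compound 1 to compound 3 (0.16 log units; within the scatter), a step that the scatter swallows. For the measured compounds named here, its furthest is compound 2, with a 7.0-fold lower number from compound 2 to compound 3 (0.84 log units; beyond the scatter), the one step in this small set that clearly exceeds the scatter; the companion step a 10-fold higher number from compound 1 to compound 2 (1.01 log units; beyond the scatter) says the same of the furan-2-yl replacement from the other side.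

Compound 4 is `CCOC(=O)c1c(N)sc(/N=C/c2ccc(F)cc2)c1C(=O)OCC`. It differs from compound 3 as follows: fluoro in place of methyl on an aromatic carbon. Going by the values given here, the only measured step that bears on a change at this position is a 1.5-fold higher number from compound 1 to compound 3 (0.16 log units; within the scatter), and it lies within the scatter. Nothing here speaks for a large move in either direction when the methyl gives way to fluoro, while the furan steps concern a different part of the molecule. The expected step is therefore a 1.2-fold lower number from compound 3 to compound 4 (0.07 log units; within the scatter), not beyond the scatter. Compound 4 is estimated in this assay at 7500 nM, with a range from 3000 nM to 19000 nM.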

Compound 4, half-maximal inhibitory concentration: 22500 nM
Compound 4: middle estimate off by 3.0-fold (0.48 log units), on the low side; the measured number lies above the stated range.
By their numbers in this assay, from the lowest: compounds 1 and 3 (each within the scatter of the next); then compound 4; then compound 2.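

In this assay, this position on the six-membered aromatic ring is not indifferent to its substituent: the earlier hydrogen-to-methyl change stayed within the scatter (a 1.5-fold higher number from compound 1 to compound 3 (0.16 log units; within the scatter)), but fluoro moves the number beyond it, both against methyl (a 2.5-fold higher number from compound 3 to compound 4 (0.40 log units; beyond the scatter)) and against hydrogen (a 3.7-fold higher number from compound 1 to compound 4 (0.57 log units; beyond the scatter)). The change of a single heavy atom on this ring therefore registers, yet the 4-fluorophenyl compound still stays clear of the furan-2-yl compound (a 2.8-fold lower number from compound 2 to compound 4 (0.44 log units; beyond the scatter)), so the largest gap in the series remains the one set by the furan-2-yl replacement. Nothing available explains why fluoro parts from hydrogen and methyl here.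

Open, from the compounds shown here alone, is whether chloro, methoxy or an amine at this position would group with fluoro or with hydrogen and methyl. Also open, going by these compounds, is whether the fluoro step persists when the ethyl esters give way to a carboxylic acid or a longer chain.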